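This account rests on a few compounds, and the source may have more. Where it says the series, first, only, none or still open, it means among the compounds named here.

Working notes on the series. In a functional assay on PC-3 cells (Homo sapiens), read by MTT assay, with a stated time of 48 h (a higher number here means a weaker inhibitor, a lower number a stronger inhibitor), compound 3 `CCn1c(C(=O)NCCN)ccc1C(CC)(CC)c1ccc(OCC(O)C(C)(C)C)c(C)c1` gives 940 nM as its value, within the scatter of compound 2 `CCn1c(C(=O)NCCN)ccc1C(CC)(CC)c1ccc(OCC(=O)C(C)(C)C)c(C)c1` at 480 nM and well apart from compound 1 `CCN(CC)CCNC(=O)c1ccc(C(CC)(CC)c2ccc(OCC(=O)C(C)(C)C)c(C)c2)n1CC` at 30 nM as the lowest number of the three.

The change to compound 4 `CCn1c(C(=O)Oc2ccc(CCO)cc2)ccc1C(CC)(CC)c1ccc(OCC(O)C(C)(C)C)c(C)c1` is a group of 10 heavy atoms (8 carbon, 2 oxygen; one six-membered aromatic ring of carbon only) in place of a group of 4 heavy atoms (2 carbon, 2 nitrogen; no ring), on a carbonyl carbon and keeps the 1-hydroxy-2,2-dimethylpropyl group of compound 3 in place. The group that leaves is (2-aminoethyl)amino. The measured step nearest to this change is a 16-fold higher number from compound 1 to compound 2 (1.20 log units; beyond the scatter) with amino in place of diethylamino on that same side chain. The other step (a 2.0-fold higher number from compound 2 to compound 3 (0.29 log units; within the scatter)) lies at the end shared by compound 3 and compound 4, so it says little here.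

For the measured compounds named here, no measured compound replaces the whole group on the carbonyl carbon, so the direction stays open. The large step seen on that side chain still argues for a wide range. The central expectation in this assay is no step beyond the scatter, estimated as a 1.2-fold lower number from compound 3 to compound 4 (0.07 log units; within the scatter) with a wide margin on both sides. The estimate for compound 4 is 800 nM with an expected range from 150 nM to 4000 nM for the coming measurement.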

Compound 4, half-maximal inhibitory concentration: 6300 nM
The estimate for compound 4 lay 7.9-fold (0.90 log units) below the measured number; measured number outside the range, above it.
By their numbers in this assay, from the lowest: compound 1; then compounds 2 and 3 (each within the scatter of the next); then compound 4.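

In this assay, replacing the whole (2-aminoethyl)amino group on the carbonyl carbon gives a 6.7-fold higher number from compound 3 to compound 4 (0.83 log units; beyond the scatter), so a change at this position, with the other neighbour of the carbonyl carbon, the aromatic carbon, left as it was, now has a measured direction. The earlier steps shown here on this side only altered the far end of the chain and kept the amide-type nitrogen, whereas this one removes that nitrogen and brings in a six-membered aromatic ring of carbon only, and the number rises here too, as it did in a 16-fold higher number from compound 1 to compound 2 (1.20 log units; beyond the scatter). Nothing available gives a measured reason for this rise in the number, and the step alone cannot separate the parts of the exchange.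

The compounds shown leave open which part of the entering group matters: the oxygen on the carbonyl carbon, the aromatic ring or the hydroxyl at the end of its chain. A secondary amide carrying the same aromatic ring, a carboxylic acid on the carbonyl carbon and a morpholine at the end of the ethylamino chain would each bear on that question.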